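Removing a bromo group from the trimacrocyclic oxime series

A few compounds are considered here, and "the series" means these few. Any claim that something is new, unique, unknown or untested is made for them only; others in the source may bear on it.

Compound 2 `O=C1N/C=C/c2ccc(c(Br)c2)Oc2cc(cc(Br)c2O)CCNC(=O)/C(=N/O)Cc2cc(Br)c(c(Br)c2)Oc2cc(cc(Br)c2O)C/C1=N\O` gives 53 nM in a functional assay on HUVEC cells (Homo sapiens) for antiproliferative activity; on this read-out higher numbers stand for weaker inhibition and lower numbers for stronger inhibition. Compound 1 `O=C1N/C=C/c2ccc(c(Br)c2)Oc2cc(cc(Br)c2O)CCNC(=O)/C(=N/O)Cc2ccc(c(Br)c2)Oc2cc(cc(Br)c2O)C/C1=N\O` gives 54 nM, a number within the scatter of compound 2, while compound 3 `N[C@@H]1Cc2cc(Br)c(c(Br)c2)Oc2cc(ccc2O)C[C@H](N)C(=O)NCCc2cc(Br)c(c(Br)c2)Oc2cc(cc(Br)c2O)CCNC1=O` gives 610 nM, the weakest inhibition among the three. Compound 4 `O=C1N/C=C/c2ccc(c(Br)c2)Oc2cc(ccc2O)CCNC(=O)/C(=N/O)Cc2cc(Br)c(c(Br)c2)Oc2cc(cc(Br)c2O)C/C1=N\O` carries hydrogen in place of bromo on an aromatic carbon. For the measured compounds named here, the only measured step of this kind is the reverse one, bromo in place of hydrogen on an aromatic carbon, which gave a 1.0-fold lower number from compound 1 to compound 2 (0.01 log units; within the scatter). That step sits at a different ring, so the bearing is indirect, but it points to no change beyond the scatter. The step of a 1.1-fold higher number from compound 2 to compound 4 (0.05 log units; within the scatter) is therefore the expectation. Compound 4 is estimated at 60 nM in this assay, with a likely range from 25 nM to 150 nM.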

Compound 4, half-maximal inhibitory concentration: 53 nM
Beside the measured number, compound 4's estimate is 1.1-fold (0.05 log units) above it; the measured number falls inside the stated range.
By their numbers in this assay, from the lowest: compounds 2, 4 and 1 (each within the scatter of the next); then compound 3.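

At this position, on an aromatic carbon ortho to a hydroxy group, hydrogen in place of bromo gives no change at the digits printed from compound 2 to compound 4 (within the scatter) in this assay. For the compounds shown here, the earlier step, a 1.0-fold lower number from compound 1 to compound 2 (0.01 log units; within the scatter), lay at a different ring, so this is the first direct reading at this carbon, and bromo here is not required to hold the number. No measurement shown offers an explanation for this result.

Open, as far as these compounds go, is whether this carbon accepts groups other than bromo and hydrogen, such as an amine or a methoxy group. Also open, from the compounds shown here alone, is whether hydrogen here combines with hydrogen at the ring changed between compound 1 and compound 2 without shifting the number.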